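This account rests on a few compounds, and the source may have more. Where it says the series, first, only, none or still open, it means among the compounds named here.

Compound 1 `CCN1C(=O)C(O)(Cc2nnn[nH]2)c2cc(Cl)ccc21`: 49500 nM
Compound 2 `O=C1N(Cc2ccc(Br)cc2)c2ccc(Cl)cc2C1(O)Cc1nnn[nH]1`: 35800 nM

Within the data shown here, in a functional assay on PA-1 cells (Homo sapiens) for antiproliferative activity, read by MTT assay, with a stated time of 48 h (a higher number here means a weaker inhibitor, a lower number a stronger inhibitor), compound 1 stands at 49500 nM, and the only other measured compound cannot be told apart from it. Compound 3 `CCN1C(=O)C(O)(Cc2nnn[nH]2)c2cc(C)ccc21` keeps the core of compound 1 but has methyl in place of chloro on an aromatic carbon. Among the measured compounds shown here, the single measured step, a 1.4-fold lower number from compound 1 to compound 2 (0.14 log units; within the scatter), puts 4-bromophenyl in place of methyl at a different site, so it bears only indirectly. For the measured compounds named here, no step at this aromatic carbon has been measured, so no shift beyond the scatter is expected. The estimated step is a 1.1-fold lower number from compound 1 to compound 3 (0.04 log units; within the scatter). Compound 3 is expected at 45000 nM, within an estimated range of 20000 nM to 95000 nM.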

Compound 3, half-maximal inhibitory concentration: > 100000 nM
Compound 3: a limit, no number (the forecaster's own chance of this, stated with the estimate: 10%); middle value at least 2.2-fold (0.34 log units) away from the limit.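

In this assay, among these compounds, methyl in place of chloro on this aromatic carbon gives an at least 2.0-fold higher number from compound 1 to compound 3 (0.30 log units; that floor lies within the scatter), the only measured step at this site. It suggests that this small swap may weaken the compound, although the floor of the step does not by itself establish a real difference. The true size of the step stays unknown, as compound 3 has a limit of the assay and not a number: the limit of > 100000 nM in this assay, at which 1 of the 3 values shown sits.

The compounds shown do not tell how a fluoro group or an amine on this aromatic carbon would read. They also leave open whether methyl there would have the same outcome alongside the 4-bromophenyl group of compound 2.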